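The source may hold more compounds than are shown below. What is called first, only, known or untested is meant among the compounds shown, and "the series" means these compounds.

In a functional assay on MCF7 cells (Homo sapiens) for inhibition, read by resazurin assay, with a stated time of 24 h (a lower number here means a stronger inhibitor, a higher number a weaker inhibitor), compound 3 `O=C1Nc2c(C(F)(F)F)cccc2C1(c1ccc(OC(F)(F)F)cc1)c1ccc(OC(F)(F)F)cc1` reads > 1000 nM, which is a limit and not a number. Compound 4 `Cc1cc(C2(c3ccc(OC(F)(F)F)cc3)C(=O)Nc3c(C(F)(F)F)cccc32)ccc1O` differs from it by one change, (4-hydroxy-3-methylphenyl in place of 4-(trifluoromethoxy)phenyl on a saturated ring carbon), with 4-hydroxy-3-methylphenyl in place of 4-(trifluoromethoxy)phenyl on a saturated ring carbon. The closest guides are two hydroxyphenyl relatives, compound 1 `O=C1Nc2c(C(F)(F)F)cccc2C1(c1ccc(OC(F)(F)F)cc1)c1ccc(O)cc1F` at 177 nM and compound 2 `O=C1Nc2c(C(F)(F)F)cccc2C1(c1ccc(OC(F)(F)F)cc1)c1c(F)cc(O)cc1F` at 549 nM. Losing the 2-fluoro-4-hydroxyphenyl group gave an at least 5.6-fold higher number from compound 1 to compound 3 (0.75 log units; beyond the scatter), while the second comparison gave only an at least 1.8-fold higher number from compound 2 to compound 3 (0.26 log units; that floor lies within the scatter). Ring substitution also counts, as adding one fluoro gave a 3.1-fold higher number from compound 1 to compound 2 (0.49 log units; beyond the scatter). Among the compounds with values here, no measured compound carries the methyl group, so the range stays wide. A modest fall in the number is expected, with an at least 4.0-fold lower number from compound 3 to compound 4 (0.60 log units; beyond the scatter). For compound 4 the estimate is 250 nM, within an expected range of 90 nM to 700 nM.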

Compound 4, half-maximal inhibitory concentration: > 1000 nM
Compound 4: only a limit was reported; the forecaster's own chance of this, stated with the estimate: 8%; at least 4.0-fold (0.60 log units) between middle value and limit.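

In this assay compound 4 gives > 1000 nM, a limit and not a number, so the 4-hydroxy-3-methylphenyl group at this saturated ring carbon leaves no exact reading. Placing it where compound 1 has 2-fluoro-4-hydroxyphenyl gave an at least 5.6-fold higher number from compound 1 to compound 4 (0.75 log units; beyond the scatter), while placing it where compound 2 has 2,6-difluoro-4-hydroxyphenyl gave an at least 1.8-fold higher number from compound 2 to compound 4 (0.26 log units; that floor lies within the scatter). The step between compound 3 and compound 4 cannot be read: the limit of > 1000 nM in this assay, at which 2 of the 4 values shown sit.

Open, on these data alone, is how a plain 4-hydroxyphenyl group, with neither fluoro nor methyl, would read here. Also open, as far as these compounds go, is how an amine or a carboxylic acid in place of the hydroxy group would read.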